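Swapping One Ring Substituent in a Weakly Active Series

The source may hold more compounds than are shown below. What is called first, only, known or untested is meant among the compounds shown, and "the series" means these compounds.

This small set of compounds was tested in a functional assay on MCF7 cells (Homo sapiens) for antiproliferative activity, read by MTT assay, with a stated time of 48 h; a lower number here means a stronger inhibitor, a higher number a weaker inhibitor. Compound 1 `COC(=O)/C(=C/c1ccccc1)CN1C(=O)[C@@H](OC)[C@H]1c1ccc(Cl)cc1` gives 15300 nM, which places it among weak inhibitors. Compound 3 `CO[C@@H]1C(=O)N(C/C(C#N)=C/c2ccccc2)[C@@H]1c1ccc(Cl)cc1Cl`, which carries a nitrile instead of the methyl ester on the chain and two chlorines on the aryl ring, gives 31900 nM in this assay. Among the measured compounds shown here, the two numbers lie close to each other, and no step between them has been worked out, so they are taken only as two separate readings of weak activity.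

Compound 2 `COC(=O)/C(=C/c1ccccc1)CN1C(=O)[C@@H](OC)[C@H]1c1cccc(C(F)(F)F)c1` was included in the study, but in this assay compound 2 shows no result reported, so no single number is available for it and its position on the scale cannot be stated.

Compound 4 `COC(=O)/C(=C/c1ccccc1)CN1C(=O)[C@@H](OC)[C@H]1c1cccc([N+](=O)[O-])c1` differs from compound 2 in one place: nitro in place of trifluoromethyl on an aromatic carbon. The shared core, the chain with its methyl ester and the phenyl group on the double bond stay the same. For the measured compounds named here, with no measured step for compound 2 and no comparable pair among the measured compounds, there is no basis for predicting a shift in either direction in this assay; the change is expected to leave the reading within the scatter of the other two weak compounds. On that basis compound 4 is estimated to give 22000 nM, with a plausible range from 6000 nM to 80000 nM.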

Compound 4, half-maximal inhibitory concentration: 15000 nM
Compound 4: the middle estimate sits 1.5-fold (0.17 log units) above what was measured; low and high end bracket the measured number.
By their numbers in this assay, from the lowest: compounds 4 and 1 (each within the scatter of the next); then compound 3.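

In this assay, among the compounds shown here, the one step that can be read is a 1.0-fold lower number from compound 1 to compound 4 (0.01 log units; within the scatter), with 3-nitrophenyl in place of 4-chlorophenyl on a saturated ring carbon, so in this pair both the group on the aromatic ring and its place on that ring differ while the reading stays within the scatter. For the compounds shown here, this is the first comparison in the set that changes only one place, and it shows that for these two compounds the exchange of the aryl group leaves the reading unmoved, though it says nothing about other aryl groups. The step from compound 2 to compound 4 cannot be read, as compound 2 has no number, and nothing in the data shown explains the result.

The compounds shown leave open whether the swap from 3-(trifluoromethyl)phenyl to 3-nitrophenyl itself changes the reading, and whether an unsubstituted phenyl ring, or an amine or a carboxylic acid on the aromatic ring, would give a reading beyond the scatter. Compound 3 differs from the others in more than one place, so the nitrile on the chain has no single-change comparison with the methyl ester.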